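Replacing the phenyl group of compound 3

The source may hold more compounds than are shown below. What is called first, only, known or untested is meant among the compounds shown, and "the series" means these compounds.

Compound 1 `O=C(N/N=C/c1ccc(O)c(Br)c1)Nc1cc2c(Nc3ccc(F)c(Cl)c3)ncnc2cc1O[C@H]1CCOC1`: 4310 nM
Compound 2 `COc1cc2ncnc(Nc3ccc(F)c(Cl)c3)c2cc1NC(=O)N/N=C/c1ccc([N+](=O)[O-])cc1`: 35100 nM
Compound 3 `COc1cc2ncnc(Nc3ccc(F)c(Cl)c3)c2cc1NC(=O)N/N=C/c1ccc(F)cc1Cl`: 28200 nM

In a functional assay on A549 cells (Homo sapiens) for cytotoxicity, read by MTT assay, with a stated time of 72 h (a higher number here means a weaker inhibitor, a lower number a stronger inhibitor), compound 3 gives 28200 nM, the second highest of the three numbers, though within the scatter of compound 2. Compound 1 lies clearly lower. Compound 4 `COc1cc2ncnc(Nc3ccc(F)c(Cl)c3)c2cc1NC(=O)N/N=C/c1ccc(O)c(Br)c1` differs from compound 3 by 3-bromo-4-hydroxyphenyl in place of 2-chloro-4-fluorophenyl on a carbon with a double bond to nitrogen. Going by the values given here, the one measured step at this place, a 1.2-fold lower number from compound 2 to compound 3 (0.10 log units; within the scatter), shows no change beyond the scatter. Among the compounds with values here, compound 1, however, carries the same 3-bromo-4-hydroxyphenyl on its own core, and no measured step separates the two changes. A moderate move towards a lower number is therefore expected in this assay. The expected step is a 2.0-fold lower number from compound 3 to compound 4 (0.30 log units; within the scatter). Compound 4 is estimated at 14000 nM, with an expected range of 5000 nM to 35000 nM.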

Compound 4, half-maximal inhibitory concentration: 28600 nM
Beside the measured number, compound 4's estimate is 2.0-fold (0.31 log units) below it; measured number inside the range.
By their numbers in this assay, from the lowest: compound 1; then compounds 3, 4 and 2 (each within the scatter of the next).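

In this assay the group on the carbon with a double bond to nitrogen again leaves the number unmoved: a 1.0-fold higher number from compound 3 to compound 4 (0.01 log units; within the scatter) and a 1.2-fold lower number from compound 2 to compound 4 (0.09 log units; within the scatter), so 3-bromo-4-hydroxyphenyl, 2-chloro-4-fluorophenyl and 4-nitrophenyl cannot be told apart on the shared core. Going by these compounds alone, the only step beyond the scatter lies at the other place, methyl in place of oxolan-3-yl on an oxygen on an aromatic ring: a 6.6-fold higher number from compound 1 to compound 4 (0.82 log units; beyond the scatter). No measurement at hand bears on why this is so. Going by these compounds, whether an amine or a carboxylic acid in place of the phenyl group would move the number remains open. So does whether oxolan-3-yl gives a similar step alongside 4-nitrophenyl or 2-chloro-4-fluorophenyl.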